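Turning the Triazole Around on the Sulfur-Bound Methylene

The compounds below may be only part of what the source reports. "The series", "measured", "known", "first", "only" and "open" are said of these compounds alone.

Within the data shown here, compound 2 `N#Cc1c(N)nc(SCn2cncn2)c(C#N)c1-c1ccc(OCC2CC2)cc1` is one of two compounds measured so far. In an assay on CHO cells for displacement of a labelled ligand from adenosine receptor A3 (Homo sapiens), read by scintillation counting, with a stated time of 120 min, tested at 1 uM (a lower number here means less inhibition, a higher number more inhibition at the concentration tested (going by the name of the read-out)), compound 2 gives 1%. Among the measured compounds shown here, its only measured neighbour is compound 1 `N#Cc1c(N)nc(SCc2nc3ccccc3[nH]2)c(C#N)c1-c1ccc(OCC2CC2)cc1`, which in this assay gives 1%; the step of no change at the digits printed from compound 1 to compound 2 (within the scatter) shows that putting a small single ring in place of a larger two-ring heteroaryl on the saturated chain carbon bound to a sulfur left the read-out where it was, and compound 2 therefore stands level with compound 1. Compound 3 `N#Cc1c(N)nc(SCc2ncn[nH]2)c(C#N)c1-c1ccc(OCC2CC2)cc1` has not been measured. It differs from compound 2 in this way: 1H-1,2,4-triazol-5-yl in place of 1H-1,2,4-triazol-1-yl on a saturated chain carbon bound to a sulfur. The two have the same atoms, joined differently, and the change sits at exactly the position already varied between compound 1 and compound 2. For the measured compounds named here, the one step that bears on this position, no change at the digits printed from compound 1 to compound 2 (within the scatter), was flat, and nothing among the measured compounds shows this position moving the read-out at all. A step of no change at the digits printed from compound 2 to compound 3 (within the scatter) is therefore expected, none beyond the scatter. Compound 3 is estimated at 1% in this assay, between -8% and 12%.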

Compound 3, a percentage reported as inhibition, at one concentration (the size of the read-out at that concentration, not a potency): 1%
The estimate for compound 3 equals the measured number at the digits printed; the measured number falls inside the stated range.
By their numbers in this assay, from the lowest: compounds 1, 2 and 3 (each within the scatter of the next).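

In this assay, putting 1H-1,2,4-triazol-5-yl in place of 1H-1,2,4-triazol-1-yl on a saturated chain carbon bound to a sulfur gave no change at the digits printed from compound 2 to compound 3 (within the scatter) and so added a second flat step at this position, this time with the ring atoms and their number unchanged and only the joining different. The two groups differ in their counts of hydrogen-bond donors and acceptors, and among these compounds that difference came with no visible shift in the read-out. The comparison with the two-ring group, no change at the digits printed from compound 1 to compound 3 (within the scatter), now shows that neither triazole separates from 1H-benzimidazol-2-yl at this place, so all three groups tested here read alike at the one concentration used.

Still open, on these data alone, is whether an amine, a carboxylic acid or a longer chain at this place would move the read-out away from the level of these three compounds, and whether the triazole swap would matter on a compound showing more inhibition. Nothing available here explains why these groups read alike.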